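The source may report more compounds than this note shows. Statements on the series, on what has been measured and on what is new or still open speak of the compounds shown alone.

Measured compounds:
- compound 1, `Cc1ccc(S(=O)(=O)N[C@H]2CC[C@@H](F)[C@@H]2C/C=C\CCCC(=O)O)cc1`: 260 nM
- compound 2, `O=C(O)CC/C=C\C[C@H]1[C@H](F)CC[C@@H]1NS(=O)(=O)c1ccc(F)cc1`: 750 nM

In a functional assay on a cell-free system (plasma) for inhibition of thromboxane A2 receptor (Homo sapiens), read by turbidimetry (a lower number here means a stronger inhibitor, a higher number a weaker inhibitor), compound 2 gives 750 nM, the highest of the two numbers; its nearest neighbour, compound 1, gives 260 nM, a gap beyond the scatter. Compound 3, `Cc1ccc(S(=O)(=O)N[C@H]2CC[C@@H](F)[C@@H]2C/C=C\CCC(=O)O)cc1`, has not been measured. It differs from compound 2 by methyl in place of fluoro on an aromatic carbon. For the measured compounds named here, no step between measured pairs that differ in one place is known. Since compound 1 carries the methyl and gives 260 nM against compound 2 at 750 nM, the step is expected to lower the number in this assay by a 2.5-fold lower number from compound 2 to compound 3 (0.40 log units; beyond the scatter). Compound 3 is estimated at 300 nM, range 120 nM to 800 nM.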

Compound 3, half-maximal inhibitory concentration: 1900 nM
Compound 3: middle estimate off by 6.3-fold (0.80 log units), on the low side; measured number outside the range, above it.
By their numbers in this assay, from the lowest: compound 1; then compound 2; then compound 3.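

In this assay, methyl in place of fluoro on an aromatic carbon, para to a large group, gives a 2.5-fold higher number from compound 2 to compound 3 (0.40 log units; beyond the scatter), so with this chain the 4-fluorophenyl compound holds the lower number. With the 4-methylphenyl kept, carboxy in place of carboxymethyl gives a 7.3-fold higher number from compound 1 to compound 3 (0.86 log units; beyond the scatter), so the chain also moves the number, and compound 1 and compound 2 differ in both places. No data here give a reason for either step.

Open, as far as these compounds go, is whether the methyl-for-fluoro step keeps its direction on the longer chain of compound 1. Also open, from the compounds shown here alone, is how a chloro or methoxy group on the same aromatic carbon would read.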